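This account rests on a few compounds, and the source may have more. Where it says the series, first, only, none or still open, it means among the compounds named here.

Measured so far in an assay on CHO cells for displacement of a labelled ligand from adenosine receptor A3 (Homo sapiens), read by scintillation counting, with a stated time of 120 min, tested at 10 uM; on this read-out higher numbers stand for more inhibition at the one concentration tested (going by the name of the read-out) and lower numbers for less inhibition:
- compound 1 `Nc1scc(CN2CCN(c3ccc(OC(F)(F)F)cc3)CC2)c1C(=O)c1ccc(Cl)cc1` gives 1%
- compound 2 `Nc1scc(CN2CCN(c3cccc4ccccc34)CC2)c1C(=O)c1ccc(Cl)cc1` gives 0%

Compound 2 stands lowest of the two numbers; its nearest neighbour is compound 1, and the step of a number 1 percentage points lower from compound 1 to compound 2 (within the scatter) lies within the scatter, so the two are not distinguishable. Both sit at the floor of this assay.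

Compound 3 `Nc1scc(CN2CCN(c3ccccc3F)CC2)c1C(=O)c1ccc(Cl)cc1` differs from compound 2 by 2-fluorophenyl in place of naphthalen-1-yl on an amine nitrogen in a ring. Among the compounds with values here, the only step that bears on it is the aryl exchange on the same ring nitrogen from compound 1 to compound 2, which moved nothing beyond the scatter. The step of a number 2 percentage points higher from compound 2 to compound 3 (within the scatter) is therefore expected to be flat. Compound 3 is estimated at 2%, within -8% to 14%.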

Compound 3, a percentage reported as inhibition, at one concentration (the size of the read-out at that concentration, not a potency): 0%
Estimate against measurement, compound 3: 2 percentage points above; the range from low to high includes it.
By their numbers in this assay, from the lowest: compounds 2, 3 and 1 (each within the scatter of the next).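

In this assay, one six-membered aromatic ring on the ring nitrogen in place of two leaves the read-out flat (no change at the digits printed from compound 2 to compound 3 (within the scatter)), and 2-fluorophenyl reads like 4-(trifluoromethoxy)phenyl (a number 1 percentage points lower from compound 1 to compound 3 (within the scatter)). Aryl groups with one ring or two, with or without fluorine, therefore all leave the series at the floor of the assay at this position. Nothing in hand explains this flat result.

Going by these compounds, all three groups are aryl on that nitrogen, so whether this position can respond at all stays open. A benzyl group, or a carboxylic acid or an amine on the phenyl ring, would bear on that, as would a change elsewhere on the shared core.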